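Methyl Where Piperidinyl and tert-Butyl Once Stood

A few compounds are considered here, and "the series" means these few. Any claim that something is new, unique, unknown or untested is made for them only; others in the source may bear on it.

Three ureas on a shared core have been measured in an assay on isolated protein for inhibition of transient receptor potential cation channel subfamily V member 1 (Homo sapiens), read by calcium flux; on this read-out lower numbers stand for stronger inhibition and higher numbers for weaker inhibition. Compound 1 `O=C(Nc1cccc2[nH]ncc12)NC1CCc2c1cccc2N1CCCCC1` gives 10 nM in this assay, and compound 2 `CC(C)(C)c1cccc2c1CCC2NC(=O)Nc1cccc2[nH]ncc12` gives 14 nM. Compound 3 `O=C(Nc1cccc2[nH]ncc12)NC1CCc2ccccc21`, which carries only hydrogen at the aromatic carbon in question, gives 151 nM, the highest of the three numbers: the step of a 15-fold higher number from compound 1 to compound 3 (1.18 log units; beyond the scatter) and the step of an 11-fold higher number from compound 2 to compound 3 (1.03 log units; beyond the scatter) are both large, while a 1.4-fold higher number from compound 1 to compound 2 (0.15 log units; within the scatter) stays within the scatter.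

Compound 4 `Cc1cccc2c1CCC2NC(=O)Nc1cccc2[nH]ncc12` has not yet been measured. It differs from compound 3 in one place: methyl in place of hydrogen on an aromatic carbon. Among the compounds with values here, two measured steps bear on this change, and both point the same way. Because a 15-fold higher number from compound 1 to compound 3 (1.18 log units; beyond the scatter) and an 11-fold higher number from compound 2 to compound 3 (1.03 log units; beyond the scatter) were large when that carbon was left bare, a group placed there again is expected to lower the number in this assay. Methyl is a group unlike either of those two, and no measured compound shows how much of that gain it recovers, so the expected step is set between no change and the full gain seen with compound 1 and compound 2. Compound 4 is therefore estimated at 50 nM, with a range from 18 nM to 140 nM, meaning an expected step of a 3.0-fold lower number from compound 3 to compound 4 (0.48 log units; beyond the scatter).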

Compound 4, half-maximal inhibitory concentration: 46 nM
Estimate against measurement, compound 4: 1.1-fold (0.04 log units) above, within the range that was stated.
By their numbers in this assay, from the lowest: compounds 1 and 2 (each within the scatter of the next); then compound 4; then compound 3.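

In this assay, the methyl group, a single carbon with no hydrogen-bond donors or acceptors, is enough to move the number at this aromatic carbon (a 3.3-fold lower number from compound 3 to compound 4 (0.52 log units; beyond the scatter)), so the gain over bare hydrogen is not confined to piperidin-1-yl and tert-butyl. Methyl nevertheless recovers only part of that gain, since replacing either of those groups with it still leaves a higher number (a 3.3-fold higher number from compound 2 to compound 4 (0.52 log units; beyond the scatter); a 4.6-fold higher number from compound 1 to compound 4 (0.66 log units; beyond the scatter)), and both of these steps lie beyond the scatter. The four compounds thus fall into three levels at this one position, with hydrogen highest, methyl next, and tert-butyl and piperidin-1-yl lowest and within the scatter of each other, though nothing available gives a reason for this pattern.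

The compounds shown leave open whether ethyl or isopropyl on this carbon would close the remaining gap, and whether methoxy or dimethylamino would match piperidin-1-yl. They also leave open whether methyl on another carbon of the same six-membered aromatic ring would lower the number at all.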